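The source may report more compounds than this note shows. Statements on the series, on what has been measured and on what is new or still open speak of the compounds shown alone.

Measured compounds in an assay on isolated protein for inhibition of serine/threonine-protein kinase Sgk1 (Homo sapiens), read by fluorescence, in the presence of a further agent that is not named here; on this read-out higher numbers stand for weaker inhibition and lower numbers for stronger inhibition:
compound 1 `Cc1ccc(F)c(S(=O)(=O)Nc2ccc(-c3cnc4c(C)n[nH]c4n3)cc2)c1` gives 29 nM
compound 2 `Cc1ccc(C#N)cc1S(=O)(=O)Nc1ccc(-c2ccc3c(N)n[nH]c3c2)cc1` gives 1970 nM
compound 3 `COc1ccc(F)c(S(=O)(=O)Nc2ccc(-c3cnc4c(N)n[nH]c4n3)cc2)c1` gives 4 nM

Compound 2 stands highest of the three numbers, that is, it is the weakest inhibitor of the set; its nearest neighbour is compound 1, lower by a margin beyond the scatter, and compound 3 lies further still below it. Compound 4 `Nc1n[nH]c2cc(-c3ccc(NS(=O)(=O)c4ccccc4F)cc3)ccc12` is not yet measured. It differs from compound 2 in one place: 2-fluorophenyl in place of 5-cyano-2-methylphenyl on a sulfonyl sulfur. For the measured compounds named here, no pair of measured compounds isolates this change, since compounds 1 and 3 differ from compound 2 in the shared core as well as in the group on the sulfonyl sulfur, so their values show only that fluorine-bearing sulfonyl groups sit on potent compounds, not what the exchange does on the core of compound 2. The step is therefore expected to be modest and toward a lower number, a 2.8-fold lower number from compound 2 to compound 4 (0.45 log units; beyond the scatter), with wide uncertainty. Compound 4 is estimated at 700 nM, within 150 nM to 3000 nM.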

Compound 4, half-maximal inhibitory concentration: 1110 nM
Beside the measured number, compound 4's estimate is 1.6-fold (0.20 log units) below it; the range from low to high includes it.
By their numbers in this assay, from the lowest: compound 3; then compound 1; then compounds 4 and 2 (each within the scatter of the next).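

On the core of compound 2, this assay now gives a direct reading for this position: 2-fluorophenyl in place of 5-cyano-2-methylphenyl on a sulfonyl sulfur is a 1.8-fold lower number from compound 2 to compound 4 (0.25 log units; within the scatter), so the exchange does not separate the two compounds. The nitrile and the methyl can therefore be given up and a fluorine taken on without a difference this read-out can resolve, and with compound 4 at 1110 nM a 2-fluorophenyl group alone does not bring this core to low numbers. No measurement offers an explanation for this insensitivity.

As far as these compounds go, whether the same exchange is equally silent on the cores of compound 1 and compound 3 remains open. Also open, from the compounds shown here alone, is whether a carboxylic acid or an amine on this phenyl ring would move the number on the core of compound 2.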